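The compounds below may be only part of what the source reports. "The series", "measured", "known", "first", "only" and "open" are said of these compounds alone.

Compounds measured so far, with their values in an assay on cells for displacement of a labelled ligand from Orexin/Hypocretin receptor type 1 (Homo sapiens), read by scintillation counting, with stated times of 10 min and 90 min, tested at 10 uM; a lower number here means less inhibition, a higher number more inhibition at the concentration tested (going by the name of the read-out):

Compound 1 `COC(=O)c1ccc2ccc(C(=O)c3ccc(C(F)(F)F)cc3)c-2cc1` gives -60.5%.
Compound 2 `O=C(O)c1ccc2ccc(C(=O)c3ccc(C(F)(F)F)cc3)c-2cc1` gives -81.5%.
Compound 3 `COC(=O)Cc1ccc2ccc(C(=O)c3ccc(C(F)(F)F)cc3)c-2cc1` gives -30.4%.

Compound 3 stands highest of the three. Its nearest neighbour is compound 1, with a step of a number 30.1 percentage points higher from compound 1 to compound 3 (beyond the scatter), and the furthest is compound 2, with a step of a number 51.1 percentage points higher from compound 2 to compound 3 (beyond the scatter). All three share one core and differ only in the group on one aromatic carbon.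

Compound 4 `O=C(O)Cc1ccc2ccc(C(=O)c3ccc(C(F)(F)F)cc3)c-2cc1` is the next compound to be tested. Its difference from compound 3 is hydrogen in place of methyl on an oxygen next to a carbonyl group.

Among the compounds with values here, one measured step bears directly on this change. The same replacement of methyl by hydrogen on an oxygen next to a carbonyl group turns compound 1 into compound 2, and there the step was a number 21 percentage points lower from compound 1 to compound 2 (beyond the scatter), beyond the scatter. The one extra carbon between the aromatic ring and the carbonyl in compound 3 and compound 4 is the only thing that sets this pair apart from that earlier pair, and there is no measurement to show whether it alters the outcome.

The expectation is therefore a downward step of similar, modest size, a number 20.6 percentage points lower from compound 3 to compound 4 (beyond the scatter). Compound 4 is estimated at -51%, with a range from -75% to -27%.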

Compound 4, a percentage reported as inhibition, at one concentration (the size of the read-out at that concentration, not a potency): 8.6%
For compound 4 the middle estimate is 59.6 percentage points below the measured one, outside the stated range (above it).
By their numbers in this assay, from the lowest: compound 2; then compound 1; then compound 3; then compound 4.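

In this assay, within the data shown here, hydrogen in place of methyl on an oxygen next to a carbonyl group gives a number 39 percentage points higher from compound 3 to compound 4 (beyond the scatter), so this change does not move the number the same way on every compound that carries it: the same change on two cores in this assay, a number 21 percentage points lower (beyond the scatter) from compound 1 to compound 2 and a number 39 percentage points higher (beyond the scatter) from compound 3 to compound 4, 60 percentage points apart, beyond the scatter of two such steps The group on the aromatic carbon therefore decides what the change does, and the acids differ far more from each other than the earlier compounds could show, with carboxymethyl in place of carboxy giving a number 90.1 percentage points higher from compound 2 to compound 4 (beyond the scatter), the largest step in the set, and carboxymethyl in place of methoxycarbonyl giving a number 69.1 percentage points higher from compound 1 to compound 4 (beyond the scatter). Of the four, only compound 4 has a positive number, 8.6%, while the other three all read negative.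

From the compounds shown here alone, whether a longer chain ending in a carboxylic acid would continue this rise, or whether an amide in place of the acid would keep it, stays open. A reading at a single concentration is also not a potency, so these numbers cannot say how strongly compound 4 acts on the receptor across a range of concentrations.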